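Chloro for Methyl on the Fused Ring: Cytotoxicity Outlook

The source may report more compounds than this note shows. Statements on the series, on what has been measured and on what is new or still open speak of the compounds shown alone.

Of the compounds shown here, three share one core and have been tested in an ADME assay on MT4 cells (Homo sapiens) for cytotoxicity, read by spectrophotometry, with a stated time of 5 days; on this read-out lower numbers stand for higher toxicity in this test and higher numbers for lower toxicity in this test. Compound 1 `CCn1cc(C(=O)O)c(=O)c2cc(F)c(N3CCN(CN4C(=O)/C(=N\NC(=S)NO)c5cc(C)ccc54)C(C)C3)c(F)c21` gives 244000 nM. Compound 2 `CCn1cc(C(=O)O)c(=O)c2cc(F)c(N3CCN(CN4C(=O)/C(=N\NC(=S)NOC)c5cc(C)ccc54)C(C)C3)c(F)c21` gives 156000 nM. Compound 3 `CCn1cc(C(=O)O)c(=O)c2cc(F)c(N3CCN(CN4C(=O)/C(=N\NC(=S)NO)c5cc(C)ccc54)CC3)cc21` gives 327000 nM. Compound 2 thus gives the lowest of the three numbers; its gap to compound 1 is within the usual scatter, while compound 3 gives a higher number that is beyond it. For the measured compounds named here, the one step between two measured compounds that differ in a single place, a 1.6-fold lower number from compound 1 to compound 2 (0.19 log units; within the scatter), concerns a methyl added on an oxygen.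

Compound 4 `CCn1cc(C(=O)O)c(=O)c2cc(F)c(N3CCN(CN4C(=O)/C(=N\NC(=S)NOC)c5cc(Cl)ccc54)C(C)C3)c(F)c21` differs from compound 2 in another place: chloro in place of methyl on an aromatic carbon. Going by the values given here, no measured pair shows a chloro in place of methyl on this aromatic carbon, so nothing among the measured compounds speaks directly to the change. With only the small step from compound 1 to compound 2 as context, no step beyond the usual scatter is expected in this assay, and compound 4 is therefore estimated at 160000 nM, with a range from 75000 nM to 340000 nM. The step is expected to be a 1.0-fold higher number from compound 2 to compound 4 (0.01 log units; within the scatter).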

Compound 4, half-maximal cytotoxic concentration: 180000 nM
Compound 4: middle estimate off by 1.1-fold (0.05 log units), on the low side, and the stated range covers the measured number.
By their numbers in this assay, from the lowest: compounds 2, 4, 1 and 3 (each within the scatter of the next, the first and the last beyond it).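

Putting chloro in place of methyl on this aromatic carbon gives a 1.2-fold higher number from compound 2 to compound 4 (0.06 log units; within the scatter) in this assay and is the first step shown at this position of the shared core. With the rest of compound 2 kept unchanged, this read-out does not separate chloro from methyl at this place, so the position tolerates this one exchange without a step beyond the scatter. No measurement available here offers an explanation for this result.

On these data alone, whether the same exchange would read alike with the free hydrogen on the oxygen, as in compound 1, remains open. As far as these compounds go, it is also open how this assay would respond to a group of a different kind on this aromatic carbon, such as an amine or a nitrile, or to a longer chain such as propyl.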